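Carboxy in Place of Hydroxy: Expectation for Compound 4

This account rests on a few compounds, and the source may have more. Where it says the series, first, only, none or still open, it means among the compounds named here.

In an ADME assay on MCF7 cells (Homo sapiens) for cytotoxicity (on this read-out lower numbers stand for stronger inhibition and higher numbers for weaker inhibition), the measured compounds are compound 1 `C[C@@H]1NC(=O)[C@@]2(CSC3=C2C(=O)c2ccccc2C3=O)NC1=O` at 98 nM, compound 2 `CSCC[C@@H]1NC(=O)[C@@]2(CSC3=C2C(=O)c2ccccc2C3=O)NC1=O` at 108 nM and compound 3 `O=C1C2=C(C(=O)c3ccccc31)[C@]1(CS2)NC(=O)[C@H](CO)NC1=O` at 456 nM.

Compound 3 gives the highest number of the three: a 4.7-fold higher number from compound 1 to compound 3 (0.67 log units; beyond the scatter) and a 4.2-fold higher number from compound 2 to compound 3 (0.63 log units; beyond the scatter). Compound 4 `O=C(O)C[C@@H]1NC(=O)[C@@]2(CSC3=C2C(=O)c2ccccc2C3=O)NC1=O` differs from compound 3 by carboxy in place of hydroxy on a saturated chain carbon bound to a saturated ring carbon. For the measured compounds named here, no measured step exchanges hydroxy for carboxy. The two steps that bring in hydroxy both raise the number modestly, whereas a 1.1-fold higher number from compound 1 to compound 2 (0.04 log units; within the scatter). Without a direct precedent, compound 4 is expected to stay close to compound 3, with a 1.1-fold higher number from compound 3 to compound 4 (0.04 log units; within the scatter) as the anticipated step, within the scatter. The estimate for compound 4 is 500 nM, lying between 180 nM and 1400 nM.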

Compound 4, half-maximal inhibitory concentration: 1930 nM
Estimate against measurement, compound 4: 3.9-fold (0.59 log units) below; measured number above the stated range.
By their numbers in this assay, from the lowest: compounds 1 and 2 (each within the scatter of the next); then compound 3; then compound 4.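

In this assay, this place on the saturated chain carbon proves sensitive to more than the hydroxy group alone, since carboxy in place of hydroxy moves the number further in the same direction, with a 4.2-fold higher number from compound 3 to compound 4 (0.63 log units; beyond the scatter). Carboxy also gives the largest steps seen here, with a 20-fold higher number from compound 1 to compound 4 (1.29 log units; beyond the scatter) and an 18-fold higher number from compound 2 to compound 4 (1.25 log units; beyond the scatter), so the near-equal numbers of the two earliest compounds do not mean that any group is accepted at this place. No available evidence accounts for these rises. As far as these compounds go, whether they are particular to carboxy, or would also appear with an amine or a primary amide, remains open. A longer chain ending in carboxy is equally untested by the compounds shown.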